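Sulfonyl aryl swap within a three-compound series

The compounds below may be only part of what the source reports. "The series", "measured", "known", "first", "only" and "open" are said of these compounds alone.

Compound 3 `CC1CCN(c2c(S(=O)(=O)c3ccc(F)cc3)cnc3ccc(Cl)cc23)CC1` gives 89% in an assay on isolated protein for displacement of a labelled ligand from metabotropic glutamate receptor 5 (Homo sapiens), with a stated time of 60 min, tested at 1 uM; on this read-out lower numbers stand for less inhibition and higher numbers for more inhibition at the one concentration tested (going by the name of the read-out). Compound 1 `CC1CCN(c2c(S(=O)(=O)c3cc(Cl)cc(Cl)c3)cnc3ccc(Cl)cc23)CC1` carries 3,5-dichlorophenyl in place of 4-fluorophenyl on a sulfonyl sulfur; in this assay compound 1 gives 88%, so that a number 1 percentage points lower from compound 3 to compound 1 (within the scatter). Compound 2 `Cc1ccc2ncc(S(=O)(=O)c3ccc(F)cc3)c(N3CCC(C)CC3)c2c1` differs from compound 3 in its core by methyl in place of chloro on an aromatic carbon; in this assay compound 2 gives 90%, and a number 1 percentage points lower from compound 2 to compound 3 (within the scatter). All three values sit close together, with no step beyond the scatter among them.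

Compound 4 `Cc1ccc2ncc(S(=O)(=O)c3cc(Cl)cc(Cl)c3)c(N3CCC(C)CC3)c2c1` is not yet measured. It carries 3,5-dichlorophenyl in place of 4-fluorophenyl on a sulfonyl sulfur, the same change as that from compound 3 to compound 1, with the place described in the same words. Among the measured compounds shown here, only this one prior instance of the change is available. In this assay the expected step is a number 1 percentage points lower from compound 2 to compound 4 (within the scatter), resting on the earlier repeat of the change, where a number 1 percentage points lower from compound 3 to compound 1 (within the scatter). Compound 4 is therefore estimated at 89%, between 82% and 95%.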

Compound 4, a percentage reported as inhibition, at one concentration (the size of the read-out at that concentration, not a potency): 75%
Compound 4: middle estimate off by 14 percentage points, on the high side, outside the stated range (below it).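

In this assay, 3,5-dichlorophenyl in place of 4-fluorophenyl on the core of compound 2 gives a number 15 percentage points lower from compound 2 to compound 4 (beyond the scatter), and methyl in place of chloro with the 3,5-dichlorophenyl group present gives a number 13 percentage points lower from compound 1 to compound 4 (beyond the scatter). This suggests that the sulfonyl change may not carry over unchanged from one core to the other, but it does not establish a dependence on the core, since the two instances stay close enough to be explained by scatter: the same change on two cores in this assay, a number 1 percentage points lower (within the scatter) from compound 3 to compound 1 and a number 15 percentage points lower (beyond the scatter) from compound 2 to compound 4, 14 percentage points apart, within the scatter of two such steps The methyl and chloro swap reads the same way: the same change on two cores in this assay, a number 1 percentage points lower (within the scatter) from compound 2 to compound 3 and a number 13 percentage points higher (beyond the scatter) from compound 4 to compound 1, 14 percentage points apart, within the scatter of two such steps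

As far as these compounds go, each change rests on only two instances, so whether the gap between them is reproducible remains open. Also open, from the compounds shown here alone, is how a phenyl carrying a single chloro or a nitrile on the sulfonyl sulfur would behave on either core.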